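This account rests on a few compounds, and the source may have more. Where it says the series, first, only, none or still open, it means among the compounds named here.

Measured compounds:

Compound 1, `COC(=O)c1cccc2c(C(=O)c3ccccc3)cc(C(=O)c3ccc(C(Cl)(Cl)Cl)cc3)c-2c1`, gives 10.4% in an assay on cells for displacement of a labelled ligand from Orexin/Hypocretin receptor type 1 (Homo sapiens), read by scintillation counting, with stated times of 10 min and 90 min, tested at 10 uM; a lower number here means less inhibition, a higher number more inhibition at the concentration tested (going by the name of the read-out).
Compound 2, `O=C(O)c1cccc2c(C(=O)c3ccccc3)cc(C(=O)c3ccc(C(Cl)(Cl)Cl)cc3)c-2c1`, gives 19.9% in this assay.
Compound 3, `COC(=O)c1ccc2ccc(C=O)c-2cc1`, gives 25% in this assay.

Compound 1 and compound 2 share a core and differ in one place: hydrogen in place of methyl on an oxygen next to a carbonyl group. The step that this change made is a number 9.5 percentage points higher from compound 1 to compound 2 (within the scatter). Compound 3 carries a different core; how its core differs from that of compound 1 is not broken down here. Among the three measured compounds compound 3 has the highest number, but its gap to compound 2 lies within the scatter, while its gap to compound 1 lies beyond it.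

Compound 4, `O=Cc1ccc2ccc(C(=O)O)ccc1-2`, has not yet been measured in this assay. It differs from compound 3 in one place: hydrogen in place of methyl on an oxygen next to a carbonyl group. Among the compounds with values here, this is the same change as the one from compound 1 to compound 2, at a place described in the same words, so the one earlier step is the only guide. The expected step is a number 6 percentage points higher from compound 3 to compound 4 (within the scatter), a small upward move like the earlier one, resting on the step of a number 9.5 percentage points higher from compound 1 to compound 2 (within the scatter), which itself lay within the scatter, so a step of either sign of similar size would not be surprising. On that basis compound 4 is expected to give about 31%, with a range from 16% to 46%.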

Compound 4, a percentage reported as inhibition, at one concentration (the size of the read-out at that concentration, not a potency): 37.8%
Compound 4: middle estimate off by 6.8 percentage points, on the low side; measured number inside the range.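

On the core of compound 3, the change from methoxycarbonyl to carboxy gave a number 12.8 percentage points higher from compound 3 to compound 4 (beyond the scatter) in this assay. Set beside the earlier case, the change behaves alike on the two cores, with both steps upward and no measurable difference in their size: the same change on two cores in this assay, a number 9.5 percentage points higher (within the scatter) from compound 1 to compound 2 and a number 12.8 percentage points higher (beyond the scatter) from compound 3 to compound 4, 3.3 percentage points apart, within the scatter of two such steps This supports carrying the change from one of these two cores to the other as a modest upward step, but it does not show that the step would hold on a third core, and only the step on the core of compound 3 stands clear of the scatter, so the pair gives no firm size for the effect and no reason for it; each number is also a read-out at a single concentration, not a potency.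

The compounds shown leave open how other groups at this place would compare with methoxycarbonyl and carboxy, for example a primary amide, a nitrile or a longer ester such as ethoxycarbonyl. They also leave open whether the same step would appear if the remaining groups on either core were replaced, for instance by an amine.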